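The compounds below may be only part of what the source reports. "The series", "measured", "known", "first", "only" and "open" are said of these compounds alone.

Compound 1: `Nc1cccc(-c2cn3nc(-c4cccs4)sc3n2)c1` — > 250000 nM
Compound 2: `C=C(Br)C(=O)Nc1cccc(-c2cn3nc(-c4ccc(CC)cc4)sc3n2)c1` — 3400 nM
Compound 3: `CCOc1ccc(-c2nn3cc(-c4cccc(N)c4)nc3s2)cc1` — > 250000 nM

The three compounds were tested in a functional assay on CCRF-CEM cells (Homo sapiens) for inhibition, read by cell counting, with a stated time of 3 days; a lower number here means a stronger inhibitor, a higher number a weaker inhibitor. For compound 1 the result is a limit of the assay, not a number: > 250000 nM. Compound 3 likewise gives only a limit, > 250000 nM. Among the compounds with values here, compound 2 is the one compound for which a number is available, 3400 nM, so it stands alone as the single measured value, with the other two results resting at the limit of > 250000 nM in this assay, at which 2 of the 3 values shown sit.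

Compound 4, `C=C(Br)C(=O)Nc1cccc(-c2cn3nc(Cc4cccc(OC)c4)sc3n2)c1`, has not yet been tested in this assay. It keeps the bromo-acrylamide side of compound 2 and changes only the group on the other side of the shared core: 3-methoxybenzyl in place of 4-ethylphenyl on an aromatic carbon. Put plainly, a 3-methoxybenzyl takes the place of a 4-ethylphenyl on an aromatic carbon, so a flexible one-carbon link now sits between the core and the outer ring, and the substituent on that ring moves from the ethyl to a methoxy group.

Within the data shown here, no step between two measured compounds is available to calibrate such a change, so the expectation rests only on compound 2. Compound 4 is expected to lose a little potency in this assay, a step of a 2.1-fold higher number from compound 2 to compound 4 (0.31 log units; beyond the scatter) that sits near the edge of the usual scatter. The estimate for compound 4 is 7000 nM, with a likely range from 1500 nM to 30000 nM.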

Compound 4, half-maximal inhibitory concentration: 3100 nM
Compound 4: the middle estimate sits 2.3-fold (0.35 log units) above what was measured, within the range that was stated.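

In this assay, putting 3-methoxybenzyl in place of 4-ethylphenyl gives a 1.1-fold lower number from compound 2 to compound 4 (0.04 log units; within the scatter), so the two compounds cannot be told apart here. Within the data shown here, this is the first step that can be read at this position, on an aromatic carbon of the five-membered ring, and it shows that the measured potency holds when a one-carbon link, a methoxy group in place of the ethyl group and a hydrogen-bond acceptor all arrive together. These differences came as a single change, so the step cannot say what each one contributes alone, and they may either matter little or cancel one another out.

Among these compounds, the remaining results add no step that can be read, since compounds 1 and 3 differ from these two in more than one place and their results are limits of the assay: the limit of > 250000 nM in this assay, at which 2 of the 4 values shown sit. Whether this position would also accept an amine, a carboxylic acid or a longer chain stays open, as does what the bromo-acrylamide contributes on its own.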